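The compounds below may be only part of what the source reports. "The series", "measured", "known", "first", "only" and "open" are said of these compounds alone.

Series values in a physicochemical assay for solubility, read by spectrophotometry, in phosphate buffer, measured as kinetic solubility, with a stated time of 18 h, at pH 7.4; on this read-out lower numbers stand for lower solubility and higher numbers for higher solubility:
- compound 1 `O=C(Nc1ccc(F)c(-c2nc3ccccc3s2)c1)c1cc([N+](=O)[O-])ccc1Cl`: 490 nM
- compound 2 `O=C(Nc1ccc(O)c(-c2nc3ccccc3s2)c1)c1cc([N+](=O)[O-])ccc1Cl`: 23 nM
- compound 3 `O=C(Nc1cccc(-c2nc3ccccc3s2)c1)c1cc([N+](=O)[O-])ccc1Cl`: 580 nM

Compound 3 at 580 nM sits at the top of the three numbers, level within the scatter with compound 1 at 490 nM, while compound 2 lies far lower at 23 nM.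

Next is compound 4 `O=C(Nc1ccc(Cl)c(-c2nc3ccccc3s2)c1)c1cc([N+](=O)[O-])ccc1Cl`, which carries chloro in place of hydrogen on an aromatic carbon, ortho to a 1,3-benzothiazol-2-yl group and para to a large group (chloro in place of hydrogen on an aromatic carbon).

For the measured compounds named here, two measured steps bear on this change. The nearer match is fluoro, also a halogen, and a 1.2-fold higher number from compound 1 to compound 3 (0.07 log units; within the scatter) stays within the scatter. The hydroxy exchange, a 25-fold higher number from compound 2 to compound 3 (1.40 log units; beyond the scatter), is large, but it involves a group that is not a halogen, so it carries less weight here. Going by the values given here, no chloro compound has been measured, which leaves fluoro as only a proxy.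

On the evidence of compound 1 at 490 nM, no step beyond the scatter is expected in this assay, with at most a slight drift to a lower number. The expected step is a 1.5-fold lower number from compound 3 to compound 4 (0.16 log units; within the scatter). For compound 4 the estimated value is 400 nM, with an expected range of 150 nM to 800 nM.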

Compound 4, solubility: 410 nM
Compound 4: middle estimate off by 1.0-fold (0.01 log units), on the low side; the range from low to high includes it.
By their numbers in this assay, from the lowest: compound 2; then compounds 4, 1 and 3 (each within the scatter of the next).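

In this assay, chloro at this place, ortho to a 1,3-benzothiazol-2-yl group and para to a large group, now has a reading of its own: a 1.4-fold lower number from compound 3 to compound 4 (0.15 log units; within the scatter) stays within the scatter, and so does a 1.2-fold lower number from compound 1 to compound 4 (0.08 log units; within the scatter), which means that hydrogen, fluoro and chloro cannot be told apart here across compound 3, compound 1 and compound 4. Compound 2 therefore stands alone among the four, since an 18-fold higher number from compound 2 to compound 4 (1.25 log units; beyond the scatter) is large, and at this place only the hydroxy compound is set apart from the others by a step beyond the scatter. Nothing on hand gives a reason for the level readings of the hydrogen and halogen compounds or for the gap to the hydroxy compound.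

Whether bromo, methyl or methoxy at the same place would stay level with these three compounds is open, as is whether an amine would read like hydroxy or like the halogens. Also open, from the compounds shown here alone, is whether these exchanges would give the same picture if a carboxylic acid took the place of the nitro group on the shared core.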